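Changing the aryl group on the ether oxygen

This account rests on a few compounds, and the source may have more. Where it says the series, first, only, none or still open, it means among the compounds named here.

Compound 1 `CC(C)(Oc1ccccc1)C1OCC(C/C=C\CCC(=O)O)C(c2cccnc2)O1` gives 75000 nM in an assay for inhibition of prostacyclin synthase (Homo sapiens), using microsomes; a higher number here means a weaker inhibitor, a lower number a stronger inhibitor.
Compound 2 `CSc1ccc(OC(C)(C)C2OCC(C/C=C\CCC(=O)O)C(c3cccnc3)O2)c([N+](=O)[O-])c1` gives 5000 nM in this assay.

Compound 2 stands lowest of these two numbers, since there was a 15-fold lower number from compound 1 to compound 2 (1.18 log units; beyond the scatter). Compound 3 `Cc1ccc(C#N)c(OC(C)(C)C2OCC(C/C=C\CCC(=O)O)C(c3cccnc3)O2)c1` carries a group of 9 heavy atoms (8 carbon, 1 nitrogen; one six-membered aromatic ring of carbon only) in place of a group of 11 heavy atoms (7 carbon, 1 nitrogen, 2 oxygen, 1 sulfur; one six-membered aromatic ring of carbon only), on an oxygen on a saturated carbon. Among the measured compounds shown here, only that one measured step bears on this change, and it was large: a substituted ring on that oxygen lowered the number far beyond the scatter. Compound 3 keeps a substituted ring but with different groups, so part of that gain is expected to remain and a moderate rise is expected, a 2.4-fold higher number from compound 2 to compound 3 (0.38 log units; beyond the scatter). Compound 3 is estimated at 12000 nM, ranging from 3000 nM to 50000 nM.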

Compound 3, half-maximal inhibitory concentration: > 100000 nM
Compound 3 was reported as a limit; the forecaster's own chance of this, stated with the estimate: 5%; middle value at least 8.3-fold (0.92 log units) from the limit.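

Compound 3 is recorded only as a limit, > 100000 nM, in this assay. Putting a substituted ring on this oxygen therefore does not lower the number by itself, and the groups on the ring decide the outcome: the data show an at least 20-fold higher number from compound 2 to compound 3 (1.30 log units; beyond the scatter). Against the plain phenyl ring they show an at least 1.3-fold higher number from compound 1 to compound 3 (0.12 log units; that floor lies within the scatter), so 2-cyano-5-methylphenyl keeps no visible gain, and its distance from compound 1 stays unknown because the number is only this: the limit of > 100000 nM in this assay, at which 1 of the 3 values shown sits.

Still open, on these data alone, is which part of the ring group in compound 2 carries its gain. Also open, as far as these compounds go, is whether an amine or a fluorine on that ring would keep it.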